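A few compounds are considered here, and "the series" means these few. Any claim that something is new, unique, unknown or untested is made for them only; others in the source may bear on it.

Of the compounds shown here, three of a shared core have been tested in an assay on isolated protein for inhibition of alpha-ketoglutarate-dependent dioxygenase alkB homolog 3 (Homo sapiens), read by polymerase chain reaction, with a stated time of 1 h; on this read-out higher numbers stand for weaker inhibition and lower numbers for stronger inhibition. Compound 1 `Cc1[nH]n(-c2nc3ccccc3[nH]2)c(=O)c1Cc1cccc(Cl)c1` gives 540 nM. Compound 3 `Cc1[nH]n(-c2nc3ccccc3[nH]2)c(=O)c1Cc1ccc(-c2ccccc2)cc1` gives 720 nM, which lies within the scatter of compound 1. Compound 2 `O=c1c(Cc2ccccc2)c(-c2ccccc2)[nH]n1-c1nc2ccccc2[nH]1` returns only a limit of the assay, > 10000 nM, and not a number. That limit is described by the limit of > 10000 nM in this assay, at which 1 of the 3 values shown sits: compound 2 stands at the weak end of the three values, and only an upper bound on its inhibition is known.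

Compound 4 `Cc1c(-c2ccccc2)[nH]n(-c2nc3ccccc3[nH]2)c1=O` has not yet been measured in this assay. It differs from compound 2 in one place: hydrogen in place of phenyl on a saturated chain carbon bound to an aromatic carbon, which, cut one bond further out, reads benzyl to methyl. Among the compounds with values here, no step between measured compounds matches this change, so the size of its effect cannot be read from the measured pairs. Compound 1 and compound 3 both carry a benzyl of some kind and both give numbers, while compound 2 does not, but they differ from compound 2 in a second place as well, so they do not settle what the change from compound 2 to compound 4 will do.

The step from compound 2 to compound 4 is therefore expected to be an at least 1.2-fold lower number from compound 2 to compound 4 (0.09 log units; that floor lies within the scatter), with wide uncertainty. Compound 4 is estimated at 8000 nM, within 2000 nM to 30000 nM, and it may well return only a limit again.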

Compound 4, half-maximal inhibitory concentration: > 10000 nM
Compound 4 ended at the assay's limit; the forecaster's own chance of this, stated with the estimate: 50%; middle value at least 1.2-fold (0.09 log units) from the limit.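

Compound 4, like compound 2, returns only a limit of the assay and not a number in this assay, so no step can be read from one to the other: the limit of > 10000 nM in this assay, at which 2 of the 4 values shown sit. The compounds shown leave open how much the change from benzyl to methyl alters inhibition, or whether it alters it at all.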